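Fluoro in Place of Methoxy on an Inactive Amide Series

A few compounds are considered here, and "the series" means these few. Any claim that something is new, unique, unknown or untested is made for them only; others in the source may bear on it.

Compound 1 `C=CC1=C(C(=O)NCc2ccccc2)C(c2ccc(OC)cc2)OC1`: > 100000 nM
Compound 2 `C=CC1=C(C(=O)Nc2ccccc2)C(c2ccc(OC)cc2)OC1`: > 100000 nM
Compound 3 `C=CC1=C(C(=O)NC2CCCCC2)C(c2ccc(OC)cc2)OC1`: > 100000 nM

In a functional assay on QGY7701 cells (Homo sapiens) for cytotoxicity, read by MTT assay, with a stated time of 24 h (on this read-out lower numbers stand for stronger inhibition and higher numbers for weaker inhibition), compound 1 gives > 100000 nM, which is a limit of the assay and not a number. Compound 2 likewise gives only a limit in this assay. Compound 3 also gives only a limit there. Compound 1 thus stands at the limit with the other two, because of the limit of > 100000 nM in this assay, at which 3 of the 3 values shown sit. The steps a step that the two limits leave unreadable from compound 1 to compound 2, a step that the two limits leave unreadable from compound 1 to compound 3 and a step that the two limits leave unreadable from compound 2 to compound 3 cannot be sized. Compound 4 `C=CC1=C(C(=O)NCc2ccccc2)C(c2ccc(F)cc2)OC1` differs from compound 1 by fluoro in place of methoxy on an aromatic carbon. Within the data shown here, no measured step touches this ring; all three concern the amide nitrogen, so no step bears on the change. Compound 4 is therefore expected to remain at the limit, estimated at 150000 nM within 30000 nM to 600000 nM. The expected step is a step that the limit leaves unreadable from compound 1 to compound 4.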

Compound 4, half-maximal inhibitory concentration: 67600 nM
Estimate against measurement, compound 4: 2.2-fold (0.35 log units) above; the range from low to high includes it.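

Replacing 4-methoxyphenyl with 4-fluorophenyl gives an at least 1.4-fold lower number from compound 1 to compound 4 (0.17 log units; that floor lies within the scatter), and that floor lies within the scatter, so the size of the change remains unsettled. Among these compounds, still, this ring position, which no amide nitrogen step touched, is the first place where a change yields a measurable value. In this assay only compound 4 gives a number, 67600 nM. The rest sit at a limit: the limit of > 100000 nM in this assay, at which 3 of the 4 values shown sit.

From the compounds shown here alone, it remains open whether chloro or an amine at this place would also leave the limit. Going by these compounds, it also remains open whether fluoro would do so with the amide groups of compound 2 and compound 3.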